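A Second Methoxy on a Bromoacrylamide Chalcone Core

The source may report more compounds than this note shows. Statements on the series, on what has been measured and on what is new or still open speak of the compounds shown alone.

Compound 1, `C=C(Br)C(=O)Nc1ccc(/C=C/C(=O)c2ccccc2)cc1`: 3900 nM
Compound 2, `C=C(Br)C(=O)Nc1ccc(/C=C/C(=O)c2cccc(OC)c2)cc1`: 2700 nM
Compound 3, `C=C(Br)C(=O)Nc1ccc(C(=O)/C=C/c2cccc(OC)c2)cc1`: 1800 nM

Of the compounds shown here, three have been tested in a functional assay on FM3A cells (Mus musculus) for antiproliferative activity, with a stated time of 48 h; a higher number here means a weaker inhibitor, a lower number a stronger inhibitor. Compound 1 and compound 2 share one core; compound 3 differs from compound 1 in more than one place, so the difference between the two cores is not broken down here. Among the three, compound 3 has the lowest number, but its gap to compound 2 lies within the scatter, so no order can be claimed between those two.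

Going by the values given here, the one change measured so far is methoxy in place of hydrogen on an aromatic carbon, which gave a 1.4-fold lower number from compound 1 to compound 2 (0.16 log units; within the scatter). The same kind of change leads to the compound not yet measured, compound 4, `C=C(Br)C(=O)Nc1ccc(C(=O)/C=C/c2ccc(OC)c(OC)c2)cc1`, which differs from compound 3 by methoxy in place of hydrogen on an aromatic carbon. The surroundings are not identical: in compound 2 the methoxy sits meta to a large group, whereas in compound 4 it sits ortho to a methoxy group and para to a large group, so this is the same kind of change rather than the same change.

Because the earlier step of a 1.4-fold lower number from compound 1 to compound 2 (0.16 log units; within the scatter) stayed within the scatter, a similarly small step, a 1.4-fold lower number from compound 3 to compound 4 (0.14 log units; within the scatter), is expected here. Compound 4 is therefore estimated at 1300 nM, with a likely range from 500 nM to 3500 nM.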

Compound 4, half-maximal inhibitory concentration: 1200 nM
For compound 4 the middle estimate is 1.1-fold (0.03 log units) above the measured one; the range from low to high includes it.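

In this assay, putting methoxy in place of hydrogen on an aromatic carbon gave a 1.5-fold lower number from compound 3 to compound 4 (0.18 log units; within the scatter). Set beside the earlier case, the same change gave steps of matching size on the two cores: the same change on two cores in this assay, a 1.4-fold lower number (0.16 log units; within the scatter) from compound 1 to compound 2 and a 1.5-fold lower number (0.18 log units; within the scatter) from compound 3 to compound 4, 1.0-fold (0.02 log units) apart, within the scatter of two such steps. This shows that, in these two pairs, the change carried from one core to the other without any large step appearing on either, even though the new methoxy in compound 4 sits ortho to a methoxy group and para to a large group; it does not show that methoxy truly strengthens inhibition, since each step on its own lies within the scatter, and two pairs are too few to set a rule for the whole series.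

The compounds shown leave open whether a different group on this aromatic carbon, such as an amine, a carboxylic acid or a longer chain like butoxy, would give a step that rises clearly beyond the scatter. They also leave open whether the same small step would appear if the methoxy were placed elsewhere on the ring, or on a third core.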